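Triazole-linked chromone series: benzyl substituent and cytotoxicity

The compounds below may be only part of what the source reports. "The series", "measured", "known", "first", "only" and "open" are said of these compounds alone.

Measured compounds:
- Compound 1 `O=c1ccoc2cc(OCc3cn(Cc4ccccc4)nn3)ccc12` gives > 300000 nM in an ADME assay on L02 cells (Homo sapiens) for cytotoxicity, read by MTT assay, with a stated time of 48 h (a higher number here means a weaker inhibitor, a lower number a stronger inhibitor), a limit of the assay.
- Compound 2 `Cc1cccc(Cn2cc(COc3ccc4c(=O)ccoc4c3)nn2)c1` gives > 300000 nM in this assay, again a limit.
- Compound 3 `N#Cc1cccc(Cn2cc(COc3ccc4c(=O)ccoc4c3)nn2)c1` gives > 300000 nM in this assay, again a limit.

Compound 3 thus stands at the same limit as the two others, as the limit of > 300000 nM in this assay, at which 3 of the 3 values shown sit, shows. The step that the two limits leave unreadable from compound 1 to compound 2 is unreadable, as are a step that the two limits leave unreadable from compound 1 to compound 3 and a step that the two limits leave unreadable from compound 2 to compound 3, since both ends sit at the limit; none of them reports a size.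

The unmeasured compound 4 `COc1ccc(Cn2cc(COc3ccc4c(=O)ccoc4c3)nn2)cc1` differs from compound 3 by 4-methoxyphenyl in place of 3-cyanophenyl on a saturated chain carbon bound to an aromatic nitrogen. The measured steps that bear on this change are those that swap the substituent on the benzyl ring: methyl, cyano and hydrogen all leave the value at the limit, so nothing read from them shows any movement in this assay. The expectation is therefore no step beyond the scatter, the value of compound 4 most likely again at the limit, with a step that the limit leaves unreadable from compound 3 to compound 4 as the estimated step. Compound 4 is estimated at 400000 nM, within 150000 nM to 1500000 nM.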

Compound 4, half-maximal inhibitory concentration: > 300000 nM
Compound 4 ended at the assay's limit (the forecaster's own chance of this, stated with the estimate: 85%); the middle value is on the limit's open side.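

No new step can be read in this assay among compound 1, compound 2, compound 3 and compound 4, because each of their values is only a limit: the limit of > 300000 nM in this assay, at which 4 of the 4 values shown sit.

The compounds shown leave open whether these benzyl substituents differ at all in this assay, and whether any substituent on the shared core gives a value inside the limit.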